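A few compounds are considered here, and "the series" means these few. Any claim that something is new, unique, unknown or untested is made for them only; others in the source may bear on it.

Of the compounds shown here, three have so far been measured in an ADME assay on A549 cells (Homo sapiens) for cytotoxicity, read by MTT assay, with a stated time of 48 h; a lower number here means a stronger inhibitor, a higher number a weaker inhibitor. Compound 1 `Cc1nc2ccccc2cc1C(=O)n1nc(C)c(C2CCCCO2)c1C` gives 143 ug/mL, compound 2 `CC(=O)N1N=C(c2cc3ccccc3nc2C)CC1/C=C/c1ccccc1` gives 93.3 ug/mL, and compound 3 `CC(=O)n1ccc(-c2cc3ccccc3nc2C)n1` gives 87 ug/mL. Compound 2 stands second highest of these three numbers; its nearest neighbour is compound 3 and its furthest is compound 1, and both gaps lie within the usual scatter. Compound 4 `CC(=O)N1N=C(c2cc3ccccc3nc2C)CC1c1ccc(N(C)C)cc1` differs from compound 2 as follows: 4-(dimethylamino)phenyl in place of 2-phenylethenyl on a saturated ring carbon. For the measured compounds named here, no step between measured compounds exists to guide this change, and the measured numbers show no separation beyond the scatter. The step of a 1.0-fold lower number from compound 2 to compound 4 (0.02 log units; within the scatter) is therefore expected to stay within the scatter. Compound 4 is expected to give about 90 ug/mL, within a range from 45 ug/mL to 180 ug/mL.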

Compound 4, half-maximal inhibitory concentration: 110 ug/mL
Estimate against measurement, compound 4: 1.2-fold (0.09 log units) below, within the range that was stated.
By their numbers in this assay, from the lowest: compounds 3, 2, 4 and 1 (each within the scatter of the next).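

In this assay, for the compounds shown here, a 1.2-fold higher number from compound 2 to compound 4 (0.07 log units; within the scatter) gives the first reading at this saturated ring carbon, where the earlier compounds offered no step that differs in one place. Here, 4-(dimethylamino)phenyl and 2-phenylethenyl show no separation, even though the change removes the double bond outside aromatic rings and brings in a nitrogen. Nothing available explains this result. The compounds shown leave open whether a methyl group on this carbon, or a carboxylic acid in place of the dimethylamino group, would also stay within the scatter.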